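Methoxy patterns on the aryl ketone of a chalcone series

The source may report more compounds than this note shows. Statements on the series, on what has been measured and on what is new or still open speak of the compounds shown alone.

Compound 1 `O=C(/C=C/c1cn(-c2ccccc2)nc1-c1ccsc1)c1ccccc1`: 4700 nM
Compound 2 `COc1cc(OC)c(C(=O)/C=C/c2cn(-c3ccccc3)nc2-c2ccsc2)c(OC)c1`: 6100 nM
Compound 3 `COc1ccc(C(=O)/C=C/c2cn(-c3ccccc3)nc2-c2ccsc2)cc1OC`: 2900 nM

Of the compounds shown here, three sharing one core have been tested in a functional assay on Huh-7 cells (Homo sapiens) for inhibition, read by sulforhodamine B assay, with a stated time of 72 h; on this read-out higher numbers stand for weaker inhibition and lower numbers for stronger inhibition. Compound 1 gives 4700 nM and stands second highest of the three numbers; compound 2 gives 6100 nM, the nearest value, and compound 3 gives 2900 nM, the furthest. All three values lie within the scatter of one another, so no order among them can be claimed.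

The unmeasured compound 4 `COc1ccc(C(=O)/C=C/c2cn(-c3ccccc3)nc2-c2ccsc2)c(OC)c1` differs from compound 1 in a single place:

2,4-dimethoxyphenyl in place of phenyl on a carbonyl carbon

For the measured compounds named here, only one measured step bears on this change. Going from compound 1 to compound 3 installs two methoxy groups on the same ring, and that step is a 1.6-fold lower number from compound 1 to compound 3 (0.21 log units; within the scatter). Compound 2, which carries three methoxy groups on that ring, also gives a value within the scatter of compound 1. Neither observation supports a step beyond the scatter in this assay for a third methoxy arrangement. Compound 4 is therefore expected to give about 4000 nM, most likely between 2000 nM and 9000 nM. The expected step is a 1.2-fold lower number from compound 1 to compound 4 (0.07 log units; within the scatter), i.e. essentially none beyond the scatter.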

Compound 4, half-maximal inhibitory concentration: 3000 nM
Compound 4: the middle estimate sits 1.3-fold (0.12 log units) above what was measured, within the range that was stated.
By their numbers in this assay, from the lowest: compounds 3, 4, 1 and 2 (each within the scatter of the next, the first and the last beyond it).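

In this assay, the 2,4-dimethoxyphenyl group on the carbonyl carbon gives a 1.6-fold lower number from compound 1 to compound 4 (0.19 log units; within the scatter), and exchanging the 3,4-dimethoxyphenyl group for it gives a 1.0-fold higher number from compound 3 to compound 4 (0.01 log units; within the scatter), so neither the phenyl group nor the 3,4-dimethoxyphenyl group can be told apart from it here. The new compound also gives this position a modest step, as hydrogen in place of one methoxy group on an aromatic carbon of the ring in compound 2 gives a 2.0-fold lower number from compound 2 to compound 4 (0.31 log units; beyond the scatter), although compound 2 and compound 1 remain within the scatter of each other. No evidence shown here accounts for this step.

The compounds shown leave open whether a dimethylamino group or a carboxylic acid on this ring, rather than methoxy groups, would move the number beyond the scatter from compound 1. They also leave open whether a single methoxy group on this ring would differ from the phenyl group of compound 1, and whether the step seen for compound 4 would hold with other groups on the rest of the shared core.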